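Methyl in place of iodo, measured once and expected again

The compounds below may be only part of what the source reports. "The series", "measured", "known", "first", "only" and "open" are said of these compounds alone.

Of the compounds shown here, three have so far been tested in a functional assay on L1210 cells (Mus musculus) for antiproliferative activity, with a stated time of 48 h; a lower number here means a stronger inhibitor, a higher number a weaker inhibitor. Compound 1 `C=C(Br)C(=O)Nc1ccc(/C=C/C(=O)c2ccc(I)cc2)cc1` gives 3400 nM. Compound 2 `C=C(Br)C(=O)Nc1ccc(/C=C/C(=O)c2ccc(C)cc2)cc1` gives 1900 nM. Compound 3 `Nc1ccc(/C=C/C(=O)c2ccc(I)cc2)cc1` gives 50000 nM, the highest of the three numbers. The step of a 1.8-fold lower number from compound 1 to compound 2 (0.25 log units; within the scatter) corresponds to the change (methyl in place of iodo on an aromatic carbon). The step of a 15-fold higher number from compound 1 to compound 3 (1.17 log units; beyond the scatter) is far larger, and it follows the loss of a whole side group on the nitrogen.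

Compound 4 `Cc1ccc(C(=O)/C=C/c2ccc(N)cc2)cc1` has not yet been measured. It differs from compound 3 by methyl in place of iodo on an aromatic carbon. This is the same change that carries compound 1 to compound 2, and it occurs twice among the compounds here; the place of the change reads the same word for word in both cases, so it is the same change set on a different core. The two cores differ by hydrogen in place of (1-bromoethenyl)carbonyl on a nitrogen on an aromatic ring.

Because the measured step of a 1.8-fold lower number from compound 1 to compound 2 (0.25 log units; within the scatter) was small, a similarly small step is expected here. The expected step of a 1.7-fold lower number from compound 3 to compound 4 (0.22 log units; within the scatter) rests on that single earlier comparison and on nothing else, so it is only an expectation. Compound 4 is expected to give about 30000 nM in this assay, with a likely range from 10000 nM to 100000 nM.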

Compound 4, half-maximal inhibitory concentration: 49000 nM
Compound 4: the middle estimate sits 1.6-fold (0.21 log units) below what was measured; the range from low to high includes it.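

On the core of compound 3, methyl in place of iodo again gives only a small step in this assay (a 1.0-fold lower number from compound 3 to compound 4 (0.01 log units; within the scatter)), and the change reads the same on both cores: (the same change on two cores in this assay, a 1.8-fold lower number (0.25 log units; within the scatter) from compound 1 to compound 2 and a 1.0-fold lower number (0.01 log units; within the scatter) from compound 3 to compound 4, 1.8-fold (0.24 log units) apart, within the scatter of two such steps). Removing the (1-bromoethenyl)carbonyl group from the nitrogen gives a large step with methyl on the ring (a 26-fold higher number from compound 2 to compound 4 (1.41 log units; beyond the scatter)), and that step also matches its counterpart with iodo on the ring: (the same change on two cores in this assay, a 15-fold higher number (1.17 log units; beyond the scatter) from compound 1 to compound 3 and a 26-fold higher number (1.41 log units; beyond the scatter) from compound 2 to compound 4, 1.8-fold (0.24 log units) apart, within the scatter of two such steps). Among these four compounds, then, the swap of iodo for methyl carries over from one core to the other with no step beyond the scatter, and the large steps appear only where the group on the nitrogen is lost, but this rests on two pairs of compounds on two cores and does not show that the swap would stay this small on any other core, nor why it is small.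

The compounds shown carry only iodo or methyl on that ring carbon, so it stays open whether fluoro, methoxy or a carboxylic acid there would also give so small a step. From the compounds shown here alone, they also carry only the free amine or the (1-bromoethenyl)carbonyl group on the nitrogen, so it stays open whether a plain acetyl group would give numbers nearer those of compound 1 and compound 2 or those of compound 3 and compound 4.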